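A few compounds are considered here, and "the series" means these few. Any claim that something is new, unique, unknown or untested is made for them only; others in the source may bear on it.

Compound 1 `CNS(=O)(=O)Nc1cccc(Cc2c(C)c3ccc(Oc4ncccn4)cc3oc2=O)c1`: 190 nM
Compound 2 `CNS(=O)(=O)Nc1cccc(Cc2c(C)c3ccc(Oc4nccs4)cc3oc2=O)c1`: 160 nM

Going by the values given here, in a functional assay on HCT-116 cells (Homo sapiens) for antiproliferative activity, read by CCK-8 assay and cell counting, with a stated time of 96 h (on this read-out higher numbers stand for weaker inhibition and lower numbers for stronger inhibition), compound 1 gives 190 nM and compound 2 gives 160 nM, so compound 1 stands within the scatter of the only other measured compound. Compound 3 `CNS(=O)(=O)Nc1cccc(Cc2c(C)c3ccc(Oc4ncccn4)cc3oc2=O)c1C` keeps the structure of compound 1 but carries methyl in place of hydrogen on an aromatic carbon. The new methyl sits on the six-membered aromatic ring of carbon only, ortho to a (methylsulfamoyl)amino group.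

Among the compounds with values here, the one measured step (a 1.2-fold lower number from compound 1 to compound 2 (0.07 log units; within the scatter)) puts 1,3-thiazol-2-yl in place of pyrimidin-2-yl on an oxygen on an aromatic ring. That step lies within the scatter, but it was taken at a different place, so it bears only weakly on the new methyl. Within the data shown here, no measured step covers a change at this carbon, which leaves both the size and the direction open. A modest step towards weaker inhibition is expected, though with little confidence, and the range is kept wide. For compound 3 the estimated value is 260 nM, with an expected range from 70 nM to 950 nM. This estimate means an expected step (a 1.4-fold higher number from compound 1 to compound 3 (0.14 log units; within the scatter)).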

Compound 3, half-maximal inhibitory concentration: 330 nM
The estimate for compound 3 lay 1.3-fold (0.10 log units) below the measured number; the measured number falls inside the stated range.
By their numbers in this assay, from the lowest: compounds 2, 1 and 3 (each within the scatter of the next, the first and the last beyond it).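

In this assay, going by these compounds alone, methyl in place of hydrogen on an aromatic carbon, ortho to a (methylsulfamoyl)amino group, gives a 1.7-fold higher number from compound 1 to compound 3 (0.24 log units; within the scatter), and this is the first reading at any carbon of the six-membered aromatic ring of carbon only. The earlier pair spoke only to the group on the oxygen, whereas this result shows that a single added methyl at this carbon, ortho to a large group, leaves the number within the scatter of compound 1 in this assay. Nothing available offers an explanation for this reading.

On these data alone, one small group at one carbon says little about what other groups would do here, so it remains open whether a fluorine, a methoxy group, an amine or a longer chain such as ethyl at this carbon would also stay within the scatter of compound 1. As far as these compounds go, it is also open whether the same methyl would read the same way with 1,3-thiazol-2-yl on the oxygen, as in compound 2.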